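Cyclopropane amide series: mirror-image pair around compound 2

A few compounds are considered here, and "the series" means these few. Any claim that something is new, unique, unknown or untested is made for them only; others in the source may bear on it.

Measured so far in a functional assay on A549 cells (Homo sapiens) for cytotoxicity, read by MTT assay, with a stated time of 48 h; a lower number here means a stronger inhibitor, a higher number a weaker inhibitor: compound 1 `CCOC(=O)[C@]1(C(=O)NCc2ccc(C)cc2)C[C@H]1c1cc(OC)c(OC)c(OC)c1` gives 13300 nM; compound 2 `CCOC(=O)[C@]1(C(=O)Nc2ccccc2Cl)C[C@H]1c1cc(OC)c(OC)c(OC)c1` gives 13400 nM.

Going by the values given here, compound 2 holds the higher of the two numbers, but compound 1 sits within the scatter of it, and the only measured step, a 1.0-fold higher number from compound 1 to compound 2 (0.00 log units; within the scatter), is itself within the scatter. Compound 3 `CCOC(=O)[C@@]1(C(=O)Nc2ccccc2Cl)C[C@@H]1c1cc(OC)c(OC)c(OC)c1` differs from compound 2 as follows: the two compounds have the same atoms and bonds and differ only in configuration as drawn: 2 of 2 stereo elements differ (all stereocentres are inverted: mirror images); a stereocentre at a saturated ring carbon is drawn R in compound 2 and S in compound 3; a stereocentre at a saturated ring carbon is drawn S in compound 2 and R in compound 3. Among the compounds with values here, no measured step inverts configuration, so nothing measured bears directly on this change; the expectation rests on the compound 2 value alone and carries a wide range. The step from compound 2 to compound 3 is expected to be a 1.1-fold higher number from compound 2 to compound 3 (0.05 log units; within the scatter). Compound 3 is estimated at 15000 nM, with a range from 4000 nM to 50000 nM.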

Compound 3, half-maximal inhibitory concentration: 29000 nM
Estimate against measurement, compound 3: 1.9-fold (0.29 log units) below; measured number inside the range.
By their numbers in this assay, from the lowest: compounds 1 and 2 (each within the scatter of the next); then compound 3.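

In this assay, swapping the amide-nitrogen group gave only a 1.0-fold higher number from compound 1 to compound 2 (0.00 log units; within the scatter), whereas inverting both ring stereocentres gives a 2.2-fold higher number from compound 2 to compound 3 (0.34 log units; beyond the scatter). Going by these compounds alone, this is the first step beyond the scatter, though a modest one, and the configuration drawn in compound 2 gives the lower number. The gap can be assigned to configuration alone: the fact that compounds 2 and 3 differ only in the configuration as drawn

From the compounds shown here alone, whether inversion gives a similar step with the 4-methylbenzyl group of compound 1 remains open. So does the effect of a carboxylic acid in place of the ethyl ester.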